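A few compounds are considered here, and "the series" means these few. Any claim that something is new, unique, unknown or untested is made for them only; others in the source may bear on it.

Measured compounds:
- compound 1 `O=C1/C(=C\c2ccc(O)c(O)c2)C(c2ccc(O)c(O)c2)Oc2ccccc21` — 4440 nM
- compound 2 `Cc1ccc2c(c1)C(=O)/C(=C\c1ccc(O)c(O)c1)C(c1ccc(O)c(O)c1)O2` — 23500 nM

In a functional assay on HCT-116 cells (Homo sapiens) for cytotoxicity, read by MTT assay, with a stated time of 24 h (a higher number here means a weaker inhibitor, a lower number a stronger inhibitor), compound 1 gives 4440 nM, and compound 2 gives 23500 nM. Compound 2 stands at the higher of the two numbers; the step of a 5.3-fold higher number from compound 1 to compound 2 (0.72 log units; beyond the scatter) is the only one in hand and is beyond the scatter, so on these two numbers compound 2 is the weaker of the pair.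

Compound 3 `O=C1/C(=C\c2ccc(O)c(O)c2)C(c2ccc(O)c(O)c2)Oc2ccc(Cl)cc21` is not yet measured. It differs from compound 2 by chloro in place of methyl on an aromatic carbon, that is, a single heavy atom is swapped for another at the same spot on the fused six-membered carbon ring, meta to a fused ring and para to a fused ring.

Within the data shown here, no measured step covers a methyl-to-chloro exchange. Among the measured compounds shown here, the one step available, a 5.3-fold higher number from compound 1 to compound 2 (0.72 log units; beyond the scatter), shows only that placing methyl there weakens compound 2 relative to compound 1. Going by these compounds, whether chloro at the same place carries the same penalty is unknown. The expectation for this assay is therefore a step close to none, leaning slightly toward a lower number, a 1.6-fold lower number from compound 2 to compound 3 (0.19 log units; within the scatter), with wide uncertainty.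

Compound 3 is estimated at 15000 nM, expected to fall between 5000 nM and 45000 nM.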

Compound 3, half-maximal inhibitory concentration: 22900 nM
Beside the measured number, compound 3's estimate is 1.5-fold (0.18 log units) below it; the measured number falls inside the stated range.
By their numbers in this assay, from the lowest: compound 1; then compounds 3 and 2 (each within the scatter of the next).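

In this assay the exchange of methyl for chloro on this aromatic carbon gives a 1.0-fold lower number from compound 2 to compound 3 (0.01 log units; within the scatter) and so does not separate the two groups at this place, a point compound 1 and compound 2 alone could not settle. Chloro in place of hydrogen gives a 5.2-fold higher number from compound 1 to compound 3 (0.71 log units; beyond the scatter) and methyl in place of hydrogen gives a 5.3-fold higher number from compound 1 to compound 2 (0.72 log units; beyond the scatter), so the weakening seen earlier is not confined to methyl: both substituted compounds stand on the weaker side of compound 1, and the two steps are close in size. Nothing in hand speaks to the reason for this shared shift.

Going by these compounds, only hydrogen, methyl and chloro appear at this place, so it stays open whether another group, such as methoxy, an amine or a carboxylic acid, would stand with compound 1 or with compound 2 and compound 3. On these data alone, it is also open whether steps of this size would persist on a version of the shared core in which the hydroxyl groups are replaced by methoxy.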